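Ester chain length and solubility in the adenosine ester series

The source may report more compounds than this note shows. Statements on the series, on what has been measured and on what is new or still open speak of the compounds shown alone.

Measured compounds:
compound 1 `CCCCCCCC(=O)OC[C@H]1O[C@@H](n2cnc3c(N)ncnc32)[C@@H](O)[C@@H]1O`: 100 ug/mL
compound 2 `CC(=O)OC[C@H]1O[C@@H](n2cnc3c(N)ncnc32)[C@@H](O)[C@@H]1O`: 6600 ug/mL

Among the compounds with values here, compound 2 stands highest of the two numbers so far in a physicochemical assay for solubility, in phosphate buffer, with a stated time of 16 h; a lower number here means a less soluble compound, a higher number a more soluble compound; its nearest neighbour is compound 1, which in this assay gives 100 ug/mL. Within the data shown here, the one measured step, a 66-fold higher number from compound 1 to compound 2 (1.82 log units; beyond the scatter), is the only comparison that bears on the next compound. Compound 3 `CC(C)CC(=O)OC[C@H]1O[C@@H](n2cnc3c(N)ncnc32)[C@@H](O)[C@@H]1O`, not yet measured in this assay, differs from compound 2 as follows: isopropyl in place of hydrogen on a saturated chain carbon bound to a carbonyl carbon. The new group is smaller than the hexyl removed in the step to compound 2, so the expected step is in the opposite direction and of intermediate size, beyond the scatter. Compound 3 is therefore expected to give a lower number, as the estimated step of an 8.3-fold lower number from compound 2 to compound 3 (0.92 log units; beyond the scatter) shows. In this assay compound 3 is expected at 800 ug/mL, with a range from 300 ug/mL to 2500 ug/mL.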

Compound 3, solubility: 19800 ug/mL
Beside the measured number, compound 3's estimate is 25-fold (1.39 log units) below it; the measured number lies above the stated range.
By their numbers in this assay, from the lowest: compound 1; then compound 2; then compound 3.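

In this assay the place on a saturated chain carbon bound to a carbonyl carbon now shows a rise on adding isopropyl, with a 3.0-fold higher number from compound 2 to compound 3 (0.48 log units; beyond the scatter) and not the fall that the hexyl pair alone suggested. Isopropyl and hexyl at this place lie far apart, with a 200-fold higher number from compound 1 to compound 3 (2.30 log units; beyond the scatter) and so the number does not fall steadily with group size across the three compounds, compound 3 being the one that goes against such a trend. Nothing available here accounts for this order.

On these data alone, whether the rise belongs to isopropyl in particular stays open, as telling this would take a straight propyl chain, a tert-butyl group or a chain longer than hexyl at this place. As far as these compounds go, how an amine or a carboxylic acid on the chain would read in this assay is equally open.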